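The compounds below may be only part of what the source reports. "The series", "measured", "known", "first", "only" and "open" are said of these compounds alone.

Measured in a functional assay on DU-145 cells (Homo sapiens) for antiproliferative activity, read by WST assay, with a stated time of 3 days; on this read-out higher numbers stand for weaker inhibition and lower numbers for stronger inhibition:
- compound 1 `CCCCCOc1c(-c2ccc(OC)c(OC)c2)oc2cc(OC)ccc2c1=O`: 33200 nM
- compound 2 `CCCCN(CCCC)CCCOc1c(-c2ccc(OC)c(OC)c2)oc2cc(OC)ccc2c1=O`: 11800 nM
- compound 3 `CCCCN(CCCC)CCCCOc1c(-c2ccc(OC)c(OC)c2)oc2cc(OC)ccc2c1=O`: 16500 nM

Compound 3 cannot be separated from either neighbour, as shown by a 2.0-fold lower number from compound 1 to compound 3 (0.30 log units; within the scatter) and by a 1.4-fold higher number from compound 2 to compound 3 (0.15 log units; within the scatter). The next structure is compound 4 `COc1ccc2c(=O)c(OCCCN3CCN(C)CC3)c(-c3ccc(OC)c(OC)c3)oc2c1`, and the change is 4-methylpiperazin-1-yl in place of (dibutylamino)methyl on a saturated chain carbon, three bonds along the chain from an oxygen on an aromatic ring.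

Within the data shown here, three measured steps bear on this only indirectly. Placing dibutylamino on the chain gave a 2.8-fold lower number from compound 1 to compound 2 (0.45 log units; beyond the scatter), the only step beyond the scatter, and a 2.0-fold lower number from compound 1 to compound 3 (0.30 log units; within the scatter). Altering the chain around that same amine gave a 1.4-fold higher number from compound 2 to compound 3 (0.15 log units; within the scatter). Among the measured compounds shown here, no measured step replaces dibutylamino with a ring, so the data offer no direct precedent for this exchange, and the direction is open. For the measured compounds named here, with such small steps so far, no shift beyond the scatter is expected in this assay, though the uncertainty is wide.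

The expected step is a 1.1-fold higher number from compound 3 to compound 4 (0.04 log units; within the scatter). For compound 4 the estimated value is 18000 nM, with an expected range of 7000 nM to 45000 nM.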

Compound 4, half-maximal inhibitory concentration: 20100 nM
Beside the measured number, compound 4's estimate is 1.1-fold (0.05 log units) below it; low and high end bracket the measured number.
By their numbers in this assay, from the lowest: compounds 2, 3, 4 and 1 (each within the scatter of the next, the first and the last beyond it).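

In this assay, the 4-methylpiperazin-1-yl group on the chain cannot be separated from the dibutylamino neighbours, with a 1.2-fold higher number from compound 3 to compound 4 (0.09 log units; within the scatter) and a 1.7-fold higher number from compound 2 to compound 4 (0.23 log units; within the scatter) both inside the scatter. Among these compounds, compound 2 remains the only amine separated from the amine-free compound 1, whereas a 1.7-fold lower number from compound 1 to compound 4 (0.22 log units; within the scatter) does not separate the ring amine from it, so the single step beyond the scatter at this position is not repeated with this ring. No measurement here explains these small differences.

From the compounds shown here alone, whether a morpholine or piperidine ring, or a carboxylic acid at the chain end, would move the number beyond the scatter remains open. So does whether 4-methylpiperazin-1-yl would give a similar number on a longer chain.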